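Swapping the Group on the Ring Nitrogen

The source may report more compounds than this note shows. Statements on the series, on what has been measured and on what is new or still open speak of the compounds shown alone.

Compound 1 `Nc1ccccc1NC(=O)c1ccc(CSC(=S)N2CCN(c3ncccn3)CC2)cc1`: 28.4%
Compound 2 `Nc1ccccc1NC(=O)c1ccc(CSC(=S)N2CCN(Cc3cccnc3)CC2)cc1`: 37.7%

In a functional assay on MGC-803 cells (Homo sapiens) for antiproliferative activity, read by CCK-8 assay, with a stated time of 72 h, tested at 2 uM (a higher number here means a stronger effect of the compound at the concentration tested, a lower number a weaker effect), compound 2 stands highest of the two numbers, but compound 1 is nearest and the step of a number 9.3 percentage points higher from compound 1 to compound 2 (within the scatter) lies within the scatter. Compound 3 `Nc1ccccc1NC(=O)c1ccc(CSC(=S)N2CCN(c3ccccc3F)CC2)cc1` is not yet measured; it differs from compound 2 by 2-fluorophenyl in place of (pyridin-3-yl)methyl on an amine nitrogen in a ring. Within the data shown here, the only measured step, a number 9.3 percentage points higher from compound 1 to compound 2 (within the scatter), also exchanges the group on this amine nitrogen in a ring and stays within the scatter, so no step beyond the scatter is expected in this assay. Compound 3 is therefore estimated at 32%, between 17% and 47%. The expected step is a number 5.7 percentage points lower from compound 2 to compound 3 (within the scatter).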

Compound 3, a percentage reported as inhibition, at one concentration (the size of the read-out at that concentration, not a potency): 33.7%
For compound 3 the middle estimate is 1.7 percentage points below the measured one, within the range that was stated.
By their numbers in this assay, from the lowest: compounds 1, 3 and 2 (each within the scatter of the next).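

In this assay, compound 3 puts 2-fluorophenyl on the amine nitrogen, a ring of carbon only, and the result is a number 4 percentage points lower from compound 2 to compound 3 (within the scatter) and a number 5.3 percentage points higher from compound 1 to compound 3 (within the scatter). All three groups at this position, with or without a methyl link and with or without ring nitrogen, thus remain within the scatter of one another. Nothing further is available to explain these numbers. Open, on these data alone, is whether a carboxylic acid, a primary amine or a longer alkyl chain on this nitrogen would give a step beyond the scatter. Also open, as far as these compounds go, is whether these three compounds would separate at another concentration.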